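Swapping Bromo for Chloro on an Aromatic Carbon

The source may report more compounds than this note shows. Statements on the series, on what has been measured and on what is new or still open speak of the compounds shown alone.

Compounds measured in a functional assay on the whole organism (strain Kunming) with Mus musculus as the target, with a stated time of 0.5 h; on this read-out lower numbers stand for an effect already at smaller amounts and higher numbers for an effect only at larger amounts of compound:
Compound 1 `COc1cc(OC)c(OC)cc1/C=C/COC(=O)/C=C/c1cc(OC)c(OC)c(OC)c1OC`: 327 umol/kg
Compound 2 `COc1cc(OC)c(OC)cc1/C=C/COC(=O)/C=C/c1ccc(Br)cc1`: 446 umol/kg

Going by the values given here, only these two compounds have values so far, and compound 2, at 446 umol/kg, lies within the usual scatter of compound 1, at 327 umol/kg. The two numbers therefore cannot be told apart, and neither compound can be ranked above the other.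

Compound 3 `COc1cc(OC)c(OC)cc1/C=C/COC(=O)/C=C/c1ccc(Cl)cc1` has yet to be tested in this assay. It departs from compound 2 by a single exchange, chloro in place of bromo on an aromatic carbon, para to a large group. Among the compounds with values here, no measured pair of compounds differs in just one place, so the data give no direct guide to the size of this step. Within the data shown here, with so small an exchange and only two values to go on, no step beyond the scatter is expected, and no direction can be favoured. The expected step is a 1.1-fold lower number from compound 2 to compound 3 (0.05 log units; within the scatter), which would stay within the scatter. For compound 3 the estimated value is 400 umol/kg, with an expected range of 200 umol/kg to 800 umol/kg.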

Compound 3, dose for half-maximal effect: 364 umol/kg
Beside the measured number, compound 3's estimate is 1.1-fold (0.04 log units) above it; measured number inside the range.
By their numbers in this assay, from the lowest: compounds 1, 3 and 2 (each within the scatter of the next).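

In this assay, going by these compounds alone, the exchange of bromo for chloro on an aromatic carbon, para to a large group, provides the first step that can be read between compounds differing in one place (a 1.2-fold lower number from compound 2 to compound 3 (0.09 log units; within the scatter)). This step lies within the scatter, so at this position the read-out does not separate the 4-bromophenyl compound from the 4-chlorophenyl compound, and the two groups cannot be ranked on the shared core. Nothing in the available data accounts for the closeness of the two values.

Within the data shown here, whether an amine, a carboxylic acid or a fluoro group on this same carbon would give a step beyond the scatter remains open, so the result says only that these two groups cannot be told apart and not how far this position tolerates change in general. On these data alone, compound 1 differs from compound 2 and compound 3 in more than one place, so steps from it cannot be read, and the contribution of the other parts of the shared core also remains open.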